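The source may hold more compounds than are shown below. What is called first, only, known or untested is meant among the compounds shown, and "the series" means these compounds.

Measured compounds:
compound 1, `Cc1ncc(-c2ccccc2NCC2=NCCN2)o1`, 110 nM
compound 2, `Cc1nc(-c2ccccc2NCC2=NCCN2)co1`, 324 nM
compound 3, `Cc1ccsc1-c1ccccc1NCC1=NCCN1`, 0.851 nM

In a functional assay for activation of Alpha-1A adrenergic receptor (Homo sapiens), read by calcium flux (a lower number here means that less compound is needed, a higher number that more compound is needed for the effect), compound 3 stands lowest of the three, with compound 1 nearest and compound 2 furthest. Both known steps into compound 3 are large: a 130-fold lower number from compound 1 to compound 3 (2.11 log units; beyond the scatter) and a 380-fold lower number from compound 2 to compound 3 (2.58 log units; beyond the scatter). Among the compounds with values here, the one step between the two oxazoles is modest, a 2.9-fold higher number from compound 1 to compound 2 (0.47 log units; beyond the scatter).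

Compound 4, `c1cnc(-c2ccccc2NCC2=NCCN2)nc1`, has not yet been measured. It differs from compound 3 in one place: pyrimidin-2-yl in place of 3-methylthiophen-2-yl on an aromatic carbon. Both large steps bear on this change, since each of them replaced a five-membered ring with two hetero atoms by the 3-methylthiophen-2-yl group and gave a large drop in this assay. Compound 4 moves the other way, from that thiophene to a six-membered ring with 2 hetero atoms and 2 hydrogen-bond acceptors, so a large rise is expected, though whether it reaches the level of compound 1 or compound 2 cannot be read from a ring that is not one of those measured. For compound 4 the estimated step is a 240-fold higher number from compound 3 to compound 4 (2.37 log units; beyond the scatter). Compound 4 is expected to give about 200 nM in this assay, with a range from 20 nM to 2000 nM.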

Compound 4, half-maximal effective concentration: 10 nM
Compound 4: middle estimate off by 20-fold (1.30 log units), on the high side; the whole stated range lies above it.
By their numbers in this assay, from the lowest: compound 3; then compound 4; then compound 1; then compound 2.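

Within this assay, the pyrimidin-2-yl group at this place on an aromatic carbon does not behave like either five-membered ring with two hetero atoms, as the number falls on going from each oxazole (in turn an 11-fold lower number from compound 1 to compound 4 (1.04 log units; beyond the scatter) and a 32-fold lower number from compound 2 to compound 4 (1.51 log units; beyond the scatter)), so hetero atoms in the ring do not by themselves set the number at the oxazole level. The 3-methylthiophen-2-yl group still gives the lowest number of the four (a 12-fold higher number from compound 3 to compound 4 (1.07 log units; beyond the scatter)), but this gap is much narrower than those separating compound 3 from the oxazoles, which shows that a ring without sulfur can come far closer to the thiophene than the oxazoles suggested. No measurement shown here explains these differences.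

Ring size, the hetero atoms and the methyl group all change together in these steps, so their separate contributions cannot be told apart: compound 4 is the only one of the four whose ring has no methyl group. A thiophen-2-yl ring without the methyl, a pyridin-2-yl ring or a methyl-substituted pyrimidine at this place would be needed to divide the effect among them.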